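Curcumin-derived dihydropyrimidinones: aryl variation at the saturated ring carbon

This account rests on a few compounds, and the source may have more. Where it says the series, first, only, none or still open, it means among the compounds named here.

Measured so far:
compound 1, `COc1cc(/C=C/C(=O)C2=C(/C=C/c3ccc(O)c(OC)c3)NC(=O)NC2c2ccc(C)cc2)ccc1O`, 29.9%
compound 2, `COc1cc(/C=C/C(=O)C2=C(/C=C/c3ccc(O)c(OC)c3)NC(=O)NC2c2c(Cl)cccc2Cl)ccc1O`, 19.2%

In a functional assay, with a stated time of 20 min, tested at 10 uM (on this read-out lower numbers stand for a weaker effect and higher numbers for a stronger effect at the one concentration tested), compound 2 stands lowest of the two numbers; the nearest is compound 1, which gives 29.9%. Among the compounds with values here, the one measured step at this position, a number 10.7 percentage points lower from compound 1 to compound 2 (beyond the scatter), is beyond the scatter but modest in size.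

Compound 3, `COc1cc(/C=C/C(=O)C2=C(/C=C/c3ccc(O)c(OC)c3)NC(=O)NC2c2cccc([N+](=O)[O-])c2)ccc1O`, is not yet measured. Its change from compound 2 is 3-nitrophenyl in place of 2,6-dichlorophenyl on a saturated ring carbon. Within the data shown here, the only step that bears on it is a number 10.7 percentage points lower from compound 1 to compound 2 (beyond the scatter), and it concerns a different pair of groups at the same saturated ring carbon, so it gives direction only weakly. The expectation for this assay is therefore a step no larger than the scatter, a number 4.8 percentage points higher from compound 2 to compound 3 (within the scatter). Compound 3 is estimated at 24%, with a range from 10% to 38%.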

Compound 3, a percentage reported as activity, at one concentration (the size of the read-out at that concentration, not a potency): 51.2%
Compound 3: middle estimate off by 27.2 percentage points, on the low side; measured number outside the range, above it.
By their numbers in this assay, from the lowest: compound 2; then compound 1; then compound 3.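

In this assay, the group on the saturated ring carbon has a larger effect than the first pair alone showed: the change to 3-nitrophenyl gives a number 32 percentage points higher from compound 2 to compound 3 (beyond the scatter) and counts as large. Measured against 4-methylphenyl, the same group gives a number 21.3 percentage points higher from compound 1 to compound 3 (beyond the scatter) and so stands above both earlier aryl groups. The position therefore tolerates a change of aryl group with a clear rise in the read-out, and the first step gave no sign of this direction. Nothing available explains why 3-nitrophenyl stands apart from the other two groups.

Whether the nitro group itself accounts for the rise remains open. Also open, as far as these compounds go, is how the read-out would respond to an amine or a carboxylic acid on the phenyl ring, or to a cyclohexyl group on the same saturated ring carbon.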